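Changing the Aromatic Amide Group in a Cell-Growth Series

The source may hold more compounds than are shown below. What is called first, only, known or untested is meant among the compounds shown, and "the series" means these compounds.

Measured so far in a functional assay on SK-BR-3 cells (Homo sapiens) for antiproliferative activity, read by MTT assay, with a stated time of 72 h; on this read-out lower numbers stand for stronger inhibition and higher numbers for weaker inhibition:
Compound 1 `CCN1CCN(c2cc(C)c3cc(NC(=O)c4ccc(C)cc4)ccc3n2)CC1` gives 11400 nM.
Compound 2 `CCN(CC)c1cc(C)c2cc(NC(=O)c3ccc(Cl)c(Cl)c3)ccc2n1` gives 41200 nM.

Of these two numbers, compound 1 holds the lower one, and the gap to compound 2 lies beyond the usual scatter of this assay . Compounds 1 and 2 differ in more than one place, so nothing can be said about what any single change contributes; the two values simply stand side by side.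

Compound 3 `CCN1CCN(c2cc(C)c3cc(NC(=O)c4cccc(F)c4)ccc3n2)CC1` keeps the shared core and the amine group of compound 1 and changes only the aromatic group on the amide: 3-fluorophenyl in place of 4-methylphenyl on a carbonyl carbon. The group that leaves and the group that enters match in heavy-atom count, and neither carries hydrogen-bond donors or acceptors. Going by the values given here, no measured pair in this set isolates a change of this kind, so there is no step to lean on. The expectation is therefore a step no larger than the scatter in this assay , in either direction; the estimated step is a 1.1-fold higher number from compound 1 to compound 3 (0.02 log units; within the scatter). Compound 3 is expected to give 12000 nM, within a range from 4000 nM to 36000 nM.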

Compound 3, half-maximal inhibitory concentration: 24900 nM
For compound 3 the middle estimate is 2.1-fold (0.32 log units) below the measured one; the measured number falls inside the stated range.
By their numbers in this assay, from the lowest: compound 1; then compounds 3 and 2 (each within the scatter of the next).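

In this assay, going by these compounds alone, the change from 4-methylphenyl to 3-fluorophenyl on a carbonyl carbon gives a 2.2-fold higher number from compound 1 to compound 3 (0.34 log units; beyond the scatter), the first step in this set that isolates a single place. It shows that this position responds to the aromatic group it carries: the two groups match in heavy-atom count and in hydrogen-bond donors and acceptors, yet the step lies beyond the scatter, though it is modest and runs toward weaker inhibition. No measurement shown here accounts for the step.

This one step combines two differences, the identity of the group on the aromatic ring and where that group sits, and the compounds shown cannot separate them; 4-fluorophenyl or 3-methylphenyl on the same amide, with the shared core and amine group kept, would pull them apart. Also open, going by these compounds, is how far this position can move the number in either direction, which a plain phenyl, a pyridyl ring or a 4-methoxyphenyl group would begin to show.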